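A few compounds are considered here, and "the series" means these few. Any claim that something is new, unique, unknown or untested is made for them only; others in the source may bear on it.

Measured in a physicochemical assay for lipophilicity, read by HPLC, at pH 7.4; on this read-out higher numbers stand for higher lipophilicity and lower numbers for lower lipophilicity:

- compound 1 `Cc1ccc([C@@H](C)Oc2cc3oc(=O)n(CCC(=O)O)c3cc2Cl)nc1`: 2.02
- compound 2 `C[C@@H](Oc1cc2oc(=O)n(CCC(=O)O)c2cc1Cl)c1ccc(Cl)cn1`: 2.65
- compound 3 `Cc1ccnc([C@@H](C)Oc2cc3oc(=O)n(CCC(=O)O)c3cc2Cl)c1`: 2.15

Compound 3 stands at 2.15, and its two measured neighbours fall on different sides of the scatter. Its nearest neighbour is reached by a step of a number 0.13 log units higher from compound 1 to compound 3 (within the scatter), and its furthest by a step of a number 0.50 log units lower from compound 2 to compound 3 (beyond the scatter).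

The next compound is compound 4 `Cc1cccc([C@@H](C)Oc2cc3oc(=O)n(CCC(=O)O)c3cc2Cl)n1`, which has the same atoms as compound 3, joined differently: 6-methylpyridin-2-yl in place of 4-methylpyridin-2-yl on a saturated chain carbon bound to an oxygen on an aromatic ring and a saturated chain carbon. Here 6-methylpyridin-2-yl takes the place of 4-methylpyridin-2-yl on a saturated chain carbon bound to an oxygen on an aromatic ring and a saturated chain carbon.

Going by the values given here, the closest precedent is the exchange of 5-methylpyridin-2-yl for 4-methylpyridin-2-yl, which gave a number 0.13 log units higher from compound 1 to compound 3 (within the scatter). The larger steps, a number 0.63 log units higher from compound 1 to compound 2 (beyond the scatter) and a number 0.50 log units lower from compound 2 to compound 3 (beyond the scatter), both involve chloro rather than a methyl group changing place, so they bear on this change far less. Among the compounds with values here, no measured compound yet carries 6-methylpyridin-2-yl, so this precedent is a single pair. A step beyond the scatter is therefore not expected in this assay.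

The expected change is a number 0.05 log units higher from compound 3 to compound 4 (within the scatter). Compound 4 is estimated at 2.2, with an expected range from 1.85 to 2.55.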

Compound 4, distribution coefficient: 2.12
Compound 4: the middle estimate sits 0.08 log units above what was measured; low and high end bracket the measured number.
By their numbers in this assay, from the lowest: compounds 1, 4 and 3 (each within the scatter of the next); then compound 2.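

Going by these compounds alone, with 6-methylpyridin-2-yl on the saturated chain carbon, this assay gives a number 0.03 log units lower from compound 3 to compound 4 (within the scatter) and a number 0.10 log units higher from compound 1 to compound 4 (within the scatter), so the single precedent among the methylpyridinyl groups now has two further pairs beside it, and compounds 1, 3 and 4 all lie within the scatter of one another. Across these three compounds, then, moving the methyl group around the pyridine gives no step that can be read, while the gap to 5-chloropyridin-2-yl holds for this third group as well, at a number 0.53 log units lower from compound 2 to compound 4 (beyond the scatter), leaving compound 2 beyond the scatter of all three methyl compounds. The measurements offer no explanation for why the three methyl compounds read alike or why compound 2 stands apart.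

Compound 2 is the only chloro compound shown, so it remains open whether 4-chloropyridin-2-yl or 6-chloropyridin-2-yl would stand with it or with the methyl compounds. From the compounds shown here alone, how a pyridin-2-yl carrying a methoxy group or an amine would read in this assay also remains open.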